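A double bond drawn the other way

The source may hold more compounds than are shown below. What is called first, only, known or untested is meant among the compounds shown, and "the series" means these compounds.

In a physicochemical assay for lipophilicity, read by HPLC (on this read-out higher numbers stand for higher lipophilicity and lower numbers for lower lipophilicity), compound 1 `O=C1/C(=C/c2ccncc2)C(c2ccccc2)Oc2ccccc21` gives 2.98 while compound 2 `O=C1/C(=C/c2ccccc2)C(c2ccccc2)Oc2ccccc21` gives 3.9 and compound 3 `Cc1ccc(/C=C2\C(=O)c3ccccc3OC2c2ccccc2)cc1` gives 4.39 as the highest number of the three, with both gaps beyond the usual scatter. Next comes compound 4 `Cc1ccc(/C=C2/C(=O)c3ccccc3OC2c2ccccc2)cc1` which has not yet been measured. The change the two compounds have the same atoms and bonds; at least one stereo element is drawn with a configuration in one of them and without one in the other: 1 of 2 stereo elements differ; a double bond is drawn Z in compound 3 and E in compound 4 leaves the same atoms and bonds in place: a double bond is drawn Z in compound 3 and E in compound 4. Going by the values given here, the only measured step, a number 0.92 log units higher from compound 1 to compound 2 (beyond the scatter) with phenyl in place of pyridin-4-yl, is modest and beyond the scatter, but it exchanges atoms, so it offers little guidance here. Among the compounds with values here, no measured pair shows what a redrawn double bond does in this assay so no step beyond the scatter is expected. The estimated change is a number 0.09 log units lower from compound 3 to compound 4 (within the scatter) and stays within the scatter. For compound 4 the expected value is 4.3 within a range of 3.85 to 4.7 on the same scale.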

Compound 4, partition coefficient: 4.36
The estimate for compound 4 lay 0.06 log units below the measured number; measured number inside the range.
By their numbers in this assay, from the lowest: compound 1; then compound 2; then compounds 4 and 3 (each within the scatter of the next).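

In this assay, going by these compounds alone, this pair is the first to change no atoms, and redrawing the double bond leaves the number within the scatter (a number 0.03 log units lower from compound 3 to compound 4 (within the scatter)). The steps to compound 4 that do exchange atoms lie beyond the scatter, both for methyl in place of hydrogen on an aromatic carbon (a number 0.46 log units higher from compound 2 to compound 4 (beyond the scatter)) and for 4-methylphenyl in place of pyridin-4-yl (a number 1.38 log units higher from compound 1 to compound 4 (beyond the scatter)). The reading of the double bond carries one caution: the fact that one of compounds 3 and 4 is drawn with a defined configuration and the other without, at the place where they differ.

As far as these compounds go, it remains open whether redrawing the double bond would also stay within the scatter with phenyl or pyridin-4-yl on the chain. Also open, from the compounds shown here alone, is how a carboxylic acid or an amine in place of the methyl would read in this assay.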